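Swapping the Hydroxyalkyl Chain for a Hydroxycyclohexyl Ring

This account rests on a few compounds, and the source may have more. Where it says the series, first, only, none or still open, it means among the compounds named here.

Measured compounds:
Compound 1 `Cc1ccc(NC(=O)c2cnc(C(C)(C)C)s2)cc1C#Cc1nn(C[C@@H](C)CO)c2ncnc(N)c12`: in an ADME assay on HepG2 cells (Homo sapiens) for antiproliferative activity, read by MTT assay, with a stated time of 72 h (on this read-out higher numbers stand for weaker inhibition and lower numbers for stronger inhibition), compound 1 gives > 10000 nM, which is a limit of the assay rather than a number.
Compound 2 `Cc1ccc(NC(=O)c2cccc(C(C)(C)C)c2)cc1C#Cc1nn([C@H]2CC[C@H](O)CC2)c2ncnc(N)c12`: in this assay compound 2 gives 4400 nM.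
Compound 3 `Cc1ccc(NC(=O)c2ccc(Cl)c(C(F)(F)F)c2)cc1C#Cc1nn(C[C@@H](C)CO)c2ncnc(N)c12`: in this assay compound 3 gives > 10000 nM, again a limit of the assay and not a number.

Compound 3 thus stands at a limit, and it shares this position with one further value shown, as the limit of > 10000 nM in this assay, at which 2 of the 3 values shown sit, records. Among the measured compounds shown here, the only measured step that touches compound 3 is a step that the two limits leave unreadable from compound 1 to compound 3, which exchanges one ring on the amide carbonyl for another; its size cannot be read, since both ends are limits. The change now considered lies elsewhere: 4-hydroxycyclohexyl in place of 2-(hydroxymethyl)propyl on an aromatic nitrogen, which gives compound 4 `Cc1ccc(NC(=O)c2ccc(Cl)c(C(F)(F)F)c2)cc1C#Cc1nn([C@H]2CC[C@H](O)CC2)c2ncnc(N)c12`. No measured step alters this group on its own, so nothing shown fixes the size or direction of the move. Compound 2 carries the same 4-hydroxycyclohexyl group and does return a number, but it also differs from compound 3 at the amide side, so it cannot be read as a step. With compound 3 itself only a limit, no step beyond the scatter can be predicted, and a further limit remains quite possible. Compound 4 is therefore expected to give about 9000 nM, within a range from 3000 nM to 30000 nM. The step this estimate implies is expected to be an at least 1.1-fold lower number from compound 3 to compound 4 (0.04 log units; that floor lies within the scatter).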

Compound 4, half-maximal inhibitory concentration: > 10000 nM
Compound 4: a limit, no number; the forecaster's own chance of this, stated with the estimate: 55%; at least 1.1-fold (0.04 log units) between middle value and limit.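

Compound 4 also ends at a limit of the assay in this assay, so placing 4-hydroxycyclohexyl on this aromatic nitrogen does not return a number when the carbonyl carries 4-chloro-3-(trifluoromethyl)phenyl, and the steps with a limit at both ends cannot be read. With 4-hydroxycyclohexyl held constant, the amide side now gives a readable comparison: 4-chloro-3-(trifluoromethyl)phenyl in place of 3-(tert-butyl)phenyl on the carbonyl carbon gives an at least 2.2-fold higher number from compound 2 to compound 4 (0.35 log units; beyond the scatter), which means weaker inhibition. Compound 2 is therefore the only compound shown with a number, while the other three share one result: the limit of > 10000 nM in this assay, at which 3 of the 4 values shown sit.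

The compounds shown do not pair 3-(tert-butyl)phenyl with 2-(hydroxymethyl)propyl, or 2-(tert-butyl)-1,3-thiazol-5-yl with 4-hydroxycyclohexyl, so it remains open whether the number for compound 2 depends on the amide group alone or on its combination with the ring on the nitrogen. On these data alone, it is also open how a 4-aminocyclohexyl group or a longer hydroxyalkyl chain at this nitrogen would read out alongside the amide group of compound 2.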